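Ether chain extension in the amidoxime series: lipophilicity notes

A few compounds are considered here, and "the series" means these few. Any claim that something is new, unique, unknown or untested is made for them only; others in the source may bear on it.

Measured so far in a physicochemical assay for lipophilicity, measured as octanol-water partition; on this read-out higher numbers stand for higher lipophilicity and lower numbers for lower lipophilicity:
compound 1 `CCO/N=C/Nc1cc(Cl)c(F)c(Cl)c1`: 4
compound 2 `CCO/N=C/Nc1cc(Cl)c(OCC(C)C)c(Cl)c1`: 5
compound 3 `C#CCc1c(Cl)cc(N/C=N/OC)cc1Cl`: 3.3

Compound 3 carries the lowest number of the three in this assay; its values against compound 1 and compound 2 both lie beyond the scatter, so it stands clearly at the bottom of this small set.

Compound 4 `C#CCc1c(Cl)cc(N/C=N/OCCOCC)cc1Cl` is the next member and differs from compound 3 by ethoxymethyl in place of hydrogen on a saturated chain carbon bound to an oxygen. For the measured compounds named here, only one measured step bears on this kind of change: the move a number 1.00 log units higher from compound 1 to compound 2 (beyond the scatter), where an alkoxy chain entered on the core. That step added four heavy atoms directly to the ring; the present change instead extends the chain on the oxygen of the amidoxime, adding carbon and one ether oxygen. The direction is expected to be the same, upward, and the size somewhat smaller, since the entering group here brings an additional acceptor oxygen rather than a pure alkyl extension.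

The expected step is a number 0.60 log units higher from compound 3 to compound 4 (beyond the scatter). Compound 4 is estimated at 3.9, within 3.4 to 4.5.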

Compound 4, partition coefficient: 3.7
The estimate for compound 4 lay 0.20 log units above the measured number, within the range that was stated.
By their numbers in this assay, from the lowest: compound 3; then compounds 4 and 1 (each within the scatter of the next); then compound 2.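

In this assay, ethoxymethyl in place of hydrogen on a saturated chain carbon bound to an oxygen gives a number 0.40 log units higher from compound 3 to compound 4 (beyond the scatter). For the compounds shown here, this is the first step read at this place, as the only earlier step, a number 1.00 log units higher from compound 1 to compound 2 (beyond the scatter), concerns an aromatic carbon. It shows that the read-out at this place moves upward on going from methoxy to 2-ethoxyethoxy, even though the entering group carries an ether oxygen. The data on the series offer no explanation for the size of this step.

With one step at this place, the compounds shown leave open whether a longer chain, such as 2-butoxyethoxy, would continue the upward move. Also open, on these data alone, is how an all-carbon chain such as pentyloxy or a terminal amine such as 2-aminoethoxy would compare with 2-ethoxyethoxy.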